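Sulfur-bearing group replaced by isopropyl on shared core

A few compounds are considered here, and "the series" means these few. Any claim that something is new, unique, unknown or untested is made for them only; others in the source may bear on it.

Compound 2 `C[S+]([O-])c1ccc(N2C(=O)C(C)(C)c3cccnc32)cc1` gives 0% in a functional assay on the whole organism (Pleural cavity) for inhibition, with Rattus norvegicus as the target, at a dose of 25 mg/kg (a higher number here means more inhibition at the dose given (going by the name of the read-out), a lower number less inhibition), and thus stands lowest of the two numbers; the nearest, compound 1 `CSc1ccc(N2C(=O)C(C)(C)c3cccnc32)cc1`, gives 37%. Going by the values given here, the only measured step is a number 37 percentage points lower from compound 1 to compound 2 (beyond the scatter). Compound 3 `CC(C)c1ccc(N2C(=O)C(C)(C)c3cccnc32)cc1` differs from compound 2 by a group of 3 heavy atoms (3 carbon; no ring) in place of a group of 3 heavy atoms (1 carbon, 1 oxygen, 1 sulfur; no ring), on an aromatic carbon. That single step bears on this change, since the group removed is the one whose arrival brought the large drop, so a rise of comparable order, with wide uncertainty, is expected in this assay. Compound 3 is estimated at 30% (range 5% to 55%), an expected step of a number 30 percentage points higher from compound 2 to compound 3 (beyond the scatter).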

Compound 3, a percentage reported as inhibition, in the whole organism at one dose (the size of the read-out at that dose, not a potency): 6%
The estimate for compound 3 lay 24 percentage points above the measured number; the range from low to high includes it.
By their numbers in this assay, from the lowest: compounds 2 and 3 (each within the scatter of the next); then compound 1.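

In this assay the exchange for isopropyl gives a number 6 percentage points higher from compound 2 to compound 3 (within the scatter) and so removing the group with sulfur and oxygen does not by itself bring the number back. Isopropyl in place of methylsulfanyl gives a number 31 percentage points lower from compound 1 to compound 3 (beyond the scatter) and so, on this aromatic carbon para to a large group, methylsulfanyl alone among the three groups stands apart. No evidence at hand accounts for this difference. As far as these compounds go, whether the sulfur atom itself matters stays open: methoxy or ethyl at this position would test that.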